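The source may report more compounds than this note shows. Statements on the series, on what has been measured and on what is new or still open speak of the compounds shown alone.

Measured in an ADME assay on K562 cells (Homo sapiens) for cytotoxicity, read by MTT assay, with a stated time of 48 h; on this read-out higher numbers stand for weaker inhibition and lower numbers for stronger inhibition:

- compound 1 `CCc1ccc(OCc2cn(CCN3CCc4cc(OC)c(OC)cc4C3)nn2)cc1`: > 100000 nM (a limit)
- compound 2 `COc1cc2c(cc1OC)CN(CCn1cc(COc3ccc(C)c(C)c3)nn1)CC2`: > 100000 nM (a limit)

Compound 2 offers only a limit and no number. Among the measured compounds shown here, the one other value, that of compound 1, is a limit too, so the limit of > 100000 nM in this assay, at which 2 of the 2 values shown sit, describes the whole measured set.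

The next compound is compound 3 `COc1cc2c(cc1OC)CN(CCn1cc(COc3ccccc3C(C)(C)C)nn1)CC2`, not yet measured. Here 2-(tert-butyl)phenyl comes in place of 3,4-dimethylphenyl on an oxygen on a saturated carbon (2-(tert-butyl)phenyl in place of 3,4-dimethylphenyl on an oxygen on a saturated carbon). The entering group, like the leaving one, is a six-membered aromatic ring of carbon only and carries no net charge.

For the measured compounds named here, the only measured step bearing on this change is a step that the two limits leave unreadable from compound 1 to compound 2. It also swaps the group on that oxygen, but it supplies no size that could be carried over. The expectation therefore rests on the position of compound 2 at > 100000 nM and on (the limit of > 100000 nM in this assay, at which 2 of the 2 values shown sit). No readable step in either direction is expected in this assay, and another limit is the likeliest report. The expected outcome is a number no higher from compound 2 to compound 3 (the limit leaves the size open). Compound 3 is estimated at 100000 nM, with an expected range from 50000 nM to 200000 nM.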

Compound 3, half-maximal inhibitory concentration: > 100000 nM
Compound 3 ended at the assay's limit; the forecaster's own chance of this, stated with the estimate: 85%; the middle value sits exactly at the limit.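

Compound 3 adds no readable step: its comparisons with compound 1 and compound 2 in this assay join limit to limit and cannot be read. Whether the phenyl groups on that oxygen differ at all in this read-out stays open, with the whole set described by one line: the limit of > 100000 nM in this assay, at which 3 of the 3 values shown sit.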